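Replacing one phenyl group by another on a shared core

A few compounds are considered here, and "the series" means these few. Any claim that something is new, unique, unknown or untested is made for them only; others in the source may bear on it.

Compound 1 `Cc1oc(-c2c(C)c(C)c(C)c(C)c2C)nc1CN1CCC(C(=O)NCCCN2C[C@H](C)C[C@H](C)C2)CC1`: 455 10^-6 cm/s
Compound 2 `Cc1oc(-c2c(Cl)cccc2C(F)(F)F)nc1CN1CCC(C(=O)NCCCN2C[C@H](C)C[C@H](C)C2)CC1`: "not determined" (no result reported)

Compound 1 was measured in a physicochemical assay for permeability, using PAMPA (a higher number here means that the compound crosses the layer faster, a lower number that the compound crosses the layer more slowly), and gives 455 10^-6 cm/s. For compound 2 this assay gives "not determined" (no result reported), so compound 2 stands nowhere on the scale shown. Compound 3 `Cc1ccc(-c2nc(CN3CCC(C(=O)NCCCN4C[C@H](C)C[C@H](C)C4)CC3)c(C)o2)c(C)c1` differs from compound 2 in one place: 2,4-dimethylphenyl in place of 2-chloro-6-(trifluoromethyl)phenyl on an aromatic carbon. With no value for compound 2, the size of the step to compound 3 cannot be read from these data; the expectation rests on compound 1 with 455 10^-6 cm/s, and no step beyond the usual scatter away from that value is expected. Compound 3 is expected to give about 350 10^-6 cm/s, in a range from 150 10^-6 cm/s to 700 10^-6 cm/s.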

Compound 3, apparent permeability: 353 10^-6 cm/s
For compound 3 the middle estimate is 1.0-fold (0.00 log units) below the measured one; the measured number falls inside the stated range.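

In this assay there is a 1.3-fold lower number from compound 1 to compound 3 (0.11 log units; within the scatter) when 2,4-dimethylphenyl takes the place of 2,3,4,5,6-pentamethylphenyl on this aromatic carbon, so these two methyl-bearing phenyl groups cannot be told apart here. The step from compound 2 to compound 3 cannot be read, since compound 2 has no number. No measurement shown explains this result. Going by these compounds, whether a phenyl group with chlorine and trifluoromethyl gives a similar number remains open. So does the outcome for a phenyl group carrying an amine or a carboxylic acid at this position.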